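Stereocentre inversion on the dichloro urea: compound 4

The source may report more compounds than this note shows. Statements on the series, on what has been measured and on what is new or still open speak of the compounds shown alone.

Compound 3 `C[C@@H](NC(=O)Nc1ccc(Cl)cc1Cl)c1ccccc1` gives 100% in an ADME assay on the whole organism with Oryza sativa as the target, tested at 10 uM (a higher number here means a weaker effect of the compound at the concentration tested, a lower number a stronger effect), the second highest of the three numbers; compound 2 `C[C@H](NC(=O)Nc1ccccc1Cl)c1ccccc1` gives 106% and compound 1 `C[C@@H](NC(=O)Nc1ccccc1Cl)c1ccccc1` gives 93%, both within the scatter of compound 3. Compound 4 `C[C@H](NC(=O)Nc1ccc(Cl)cc1Cl)c1ccccc1` is not yet measured. the two compounds have the same atoms and bonds and differ only in configuration as drawn: 1 of 1 stereo elements differ; a stereocentre at a saturated chain carbon is drawn R in compound 3 and S in compound 4 The step that bears on this is a number 13 percentage points higher from compound 1 to compound 2 (beyond the scatter), a modest rise; it is the only comparison of this kind in the series, and its weight rests on (the fact that compounds 1 and 2 differ only in the configuration as drawn). The added chloro itself changed little, as a number 7 percentage points higher from compound 1 to compound 3 (within the scatter) shows. A modest upward step is therefore expected for compound 4, a number 10 percentage points higher from compound 3 to compound 4 (within the scatter). Compound 4 is estimated at 110%, with a range from 96% to 124%.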

Compound 4, a percentage reported as activity, at one concentration (the size of the read-out at that concentration, not a potency): 99%
For compound 4 the middle estimate is 11 percentage points above the measured one, within the range that was stated.
By their numbers in this assay, from the lowest: compounds 1, 4, 3 and 2 (each within the scatter of the next, the first and the last beyond it).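

In this assay, the inversion on the core of compound 3 gives a number 1 percentage points lower from compound 3 to compound 4 (within the scatter), so the step beyond the scatter on the first pair, a number 13 percentage points higher from compound 1 to compound 2 (beyond the scatter), does not recur on this core; the comparison is a clean one: the fact that compounds 3 and 4 differ only in the configuration as drawn

Chloro in place of hydrogen on an aromatic carbon, now read in the second configuration, gives a number 7 percentage points lower from compound 2 to compound 4 (within the scatter): the same change on two cores in this assay, a number 7 percentage points higher (within the scatter) from compound 1 to compound 3 and a number 7 percentage points lower (within the scatter) from compound 2 to compound 4, 14 percentage points apart, within the scatter of two such steps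

Going by these compounds, whether an amine or a carboxylic acid in place of the added chloro would move the number beyond the scatter stays open. So does whether the configuration step would then return.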